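Chloro to Acetamido Among Closely Matched Values

The compounds below may be only part of what the source reports. "The series", "measured", "known", "first", "only" and "open" are said of these compounds alone.

Three closely related compounds have been measured in a functional assay on HepG2 cells (Homo sapiens) for cytotoxicity, read by MTT assay, with a stated time of 24 h; a lower number here means a stronger inhibitor, a higher number a weaker inhibitor. Compound 1 (`CC(=O)Nc1ccc(S(=O)(=O)N2C/C(=C\c3cccnc3)C(=O)/C(=C/c3ccccc3C(F)(F)F)C2)cc1`) gives 4330 nM, compound 2 (`O=C1/C(=C/c2ccncc2)CN(S(=O)(=O)c2ccccc2)C/C1=C\c1ccccc1C(F)(F)F`) gives 7020 nM, and compound 3 (`O=C1/C(=C/c2ccncc2)CN(S(=O)(=O)c2ccc(Cl)cc2)C/C1=C\c1ccccc1C(F)(F)F`) gives 7190 nM. Compound 3 stands level with compound 2, and its gap to compound 1 also lies within the scatter, so the three values cannot be ranked.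

Compound 4 (`CC(=O)Nc1ccc(S(=O)(=O)N2C/C(=C\c3ccncc3)C(=O)/C(=C/c3ccccc3C(F)(F)F)C2)cc1`) differs from compound 3 at one place: acetamido in place of chloro on an aromatic carbon. This puts acetamido in place of chloro on an aromatic carbon, para to a large group, turning 4-chlorophenyl into 4-acetamidophenyl.

Two measurements bear on this change. For the measured compounds named here, the only measured step at that place, a 1.0-fold higher number from compound 2 to compound 3 (0.01 log units; within the scatter), swaps hydrogen for chloro and stays within the scatter. Compound 1 already carries the acetamido group, and its 4330 nM lies within the scatter of the value of compound 3. Neither result points to a step beyond the scatter, so none is expected in this assay, and the estimate leans only slightly toward the value of compound 1. The expected change is a 1.3-fold lower number from compound 3 to compound 4 (0.12 log units; within the scatter). For compound 4 the estimated value is 5500 nM, with an expected range from 3000 nM to 10000 nM.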

Compound 4, half-maximal inhibitory concentration: 4840 nM
The estimate for compound 4 lay 1.1-fold (0.06 log units) above the measured number, within the range that was stated.
By their numbers in this assay, from the lowest: compounds 1, 4, 2 and 3 (each within the scatter of the next).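

At the aromatic carbon para to a large group, this assay can now be read for hydrogen, chloro and acetamido on compounds that share pyridin-4-yl, and the larger acetamido group, with its hydrogen-bond donor and acceptor, gives no step beyond the scatter: the change is a 1.5-fold lower number from compound 3 to compound 4 (0.17 log units; within the scatter) when it replaces chloro, and a 1.5-fold lower number from compound 2 to compound 4 (0.16 log units; within the scatter) when it replaces hydrogen. For the compounds shown here, for the first time the pyridine change can also be read alone, with acetamido held constant, and pyridin-4-yl in place of pyridin-3-yl gives a 1.1-fold higher number from compound 1 to compound 4 (0.05 log units; within the scatter) as a step that likewise stays within the scatter. Among these four compounds, neither place has moved the number beyond the scatter, and no accompanying measurement offers an explanation for these results.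

The compounds shown leave open whether a primary amine, a carboxylic acid or a chain longer than acetamido at this aromatic carbon would give a step beyond the scatter. They also leave open what a methoxy group in place of trifluoromethyl would do to the number.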